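Aryl swap on the saturated ring carbon

The compounds below may be only part of what the source reports. "The series", "measured", "known", "first", "only" and "open" are said of these compounds alone.

Among the measured compounds shown here, compound 1 `N#CC1=C(N)N(c2ccc(S(N)(=O)=O)cc2)C2=C(CCCC2)C1c1ccccc1O` holds the larger of the two numbers measured so far, yet within the scatter of its only neighbour: in a functional assay on Ehrlich cells (Mus musculus) for cytotoxicity, read by trypan blue exclusion, with a stated time of 2 h, tested at 10 ug/mL (on this read-out higher numbers stand for a stronger effect at the one concentration tested and lower numbers for a weaker effect), compound 1 gives 10%. Compound 2 `N#CC1=C(N)N(c2ccc(S(N)(=O)=O)cc2)C2=C(CCCC2)C1c1ccc([N+](=O)[O-])cc1` gives 0% in this assay, and a number 10 percentage points lower from compound 1 to compound 2 (within the scatter). Compound 3 `Cc1ccc(C2C(C#N)=C(N)N(c3ccc(S(N)(=O)=O)cc3)C3=C2CCCC3)o1` differs from compound 1 by 5-methylfuran-2-yl in place of 2-hydroxyphenyl on a saturated ring carbon. For the measured compounds named here, the one measured step that bears on such an aryl exchange stayed within the scatter, so no step beyond the scatter is expected, the estimate being a number 5 percentage points lower from compound 1 to compound 3 (within the scatter). Compound 3 is therefore estimated at 5%, range 0% to 20%.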

Compound 3, a percentage reported as activity, at one concentration (the size of the read-out at that concentration, not a potency): 0%
For compound 3 the middle estimate is 5 percentage points above the measured one; measured number inside the range.
By their numbers in this assay, from the lowest: compounds 2, 3 and 1 (each within the scatter of the next).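

Even a five-membered aromatic ring at this position, with one heavy atom fewer than 2-hydroxyphenyl, changes little in this assay: the exchange gives a number 10 percentage points lower from compound 1 to compound 3 (within the scatter). The two replacement groups also stay together, with no change at the digits printed from compound 2 to compound 3 (within the scatter), and leaving out the hydrogen-bond donor of 2-hydroxyphenyl produces no step beyond the scatter. No available evidence explains this flat read-out. From the compounds shown here alone, it remains open whether a phenyl ring bearing an amine or a carboxylic acid, or a longer chain on the saturated ring carbon, would produce a step beyond the scatter.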